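A few compounds are considered here, and "the series" means these few. Any claim that something is new, unique, unknown or untested is made for them only; others in the source may bear on it.

Among the compounds with values here, compound 1 `O=C(/C=C/c1ccc2c(c1)B(O)OC2)c1ccc(F)cc1` gives 1600 nM in a functional assay on MDA-MB-231 cells (Homo sapiens) for cytotoxicity, read by MTT assay, with a stated time of 48 h (a higher number here means a weaker inhibitor, a lower number a stronger inhibitor), the lowest of the three numbers measured so far. Compound 2 `O=C(/C=C/c1ccc2c(c1)B(O)OC2)c1ccc(C(F)(F)F)cc1` gives 9200 nM, and compound 3 `O=C(/C=C/c1ccc2c(c1)B(O)OC2)c1ccc([N+](=O)[O-])cc1` gives 11200 nM. The measured steps are a 5.8-fold higher number from compound 1 to compound 2 (0.76 log units; beyond the scatter) and a 7.0-fold higher number from compound 1 to compound 3 (0.85 log units; beyond the scatter), while a 1.2-fold higher number from compound 2 to compound 3 (0.09 log units; within the scatter). Compound 4 `O=C(/C=C/c1ccc2c(c1)B(O)OC2)c1ccccc1F` keeps the atoms of compound 1 but joins them differently: 2-fluorophenyl in place of 4-fluorophenyl on a carbonyl carbon. Within the data shown here, none of the measured steps moves the fluoro; each exchanges it for another group, and both exchanges raised the number. Among the measured compounds shown here, the step to compound 4 thus has no direct precedent among them, and no move beyond the scatter is expected in this assay. Compound 4 is therefore estimated at 2200 nM, within 800 nM to 6500 nM, so that the expected step is a 1.4-fold higher number from compound 1 to compound 4 (0.14 log units; within the scatter).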

Compound 4, half-maximal inhibitory concentration: 2200 nM
Estimate against measurement, compound 4: no gap at the digits printed; the range from low to high includes it.
By their numbers in this assay, from the lowest: compounds 1 and 4 (each within the scatter of the next); then compounds 2 and 3 (each within the scatter of the next).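

In this assay, moving the fluoro gives a 1.4-fold higher number from compound 1 to compound 4 (0.14 log units; within the scatter) and so leaves 2-fluorophenyl and 4-fluorophenyl on a carbonyl carbon not told apart. The earlier steps shown here all exchanged the fluoro for another group and all raised the number beyond the scatter, while this one keeps the fluoro and changes only how it is joined. Nothing at hand gives a reason for this result. Open is where an amine or a methoxy group in place of the fluoro would fall, since the compounds shown carry only fluoro, trifluoromethyl and nitro on this ring.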